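Hydroxy for dimethylamino on the compound 3 side chain

The compounds below may be only part of what the source reports. "The series", "measured", "known", "first", "only" and "open" are said of these compounds alone.

Measured in a functional assay on A549 cells (Homo sapiens) for antiproliferative activity, read by MTT assay, with a stated time of 48 h; a lower number here means a stronger inhibitor, a higher number a weaker inhibitor:
compound 1 `C=C(c1cc(OC)c(OC)c(OC)c1)c1ccc(OC)cc1NC(=O)CO`: 20 nM
compound 2 `C=C(c1cc(OC)c(OC)c(OC)c1)c1ccc(OC)c(O)c1NC(C)=O`: 80 nM
compound 3 `C=C(c1cc(OC)c(OC)c(OC)c1)c1ccc(OC)c(O)c1NC(=O)CN(C)C`: 50 nM

Compound 3 lies within the scatter of compound 2, while compound 1 has a lower number than compound 3, beyond the scatter. The next compound to be read is compound 4 `C=C(c1cc(OC)c(OC)c(OC)c1)c1ccc(OC)c(O)c1NC(=O)CO`, which has hydroxy in place of dimethylamino on a saturated chain carbon bound to a carbonyl carbon. Among the compounds with values here, one measured step bears on this place: a 1.6-fold lower number from compound 2 to compound 3 (0.20 log units; within the scatter), within the scatter. Compound 1 also carries hydroxy at this place, on a different core, and gives 20 nM, but the effect of that core difference has not been measured. Based on the step to compound 3 a 1.6-fold lower number from compound 2 to compound 3 (0.20 log units; within the scatter), no step beyond the scatter is expected in this assay, with a slight lean towards a lower number. The expected change is a 1.4-fold lower number from compound 3 to compound 4 (0.15 log units; within the scatter). For compound 4 the estimate is 35 nM, with an expected range of 15 nM to 90 nM.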

Compound 4, half-maximal inhibitory concentration: 10 nM
Beside the measured number, compound 4's estimate is 3.5-fold (0.54 log units) above it; measured number below the stated range.
By their numbers in this assay, from the lowest: compounds 4 and 1 (each within the scatter of the next); then compounds 3 and 2 (each within the scatter of the next).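

Hydroxy on the saturated chain carbon bound to a carbonyl carbon sets this place apart in this assay: it differs clearly from dimethylamino (a 5.0-fold lower number from compound 3 to compound 4 (0.70 log units; beyond the scatter)) and from hydrogen (an 8.0-fold lower number from compound 2 to compound 4 (0.90 log units; beyond the scatter)), whereas the earlier exchange of hydrogen for dimethylamino stayed within the scatter (a 1.6-fold lower number from compound 2 to compound 3 (0.20 log units; within the scatter)). Hydroxy in place of hydrogen on an aromatic carbon of the core does not separate the two compounds carrying the hydroxy side chain (a 2.0-fold lower number from compound 1 to compound 4 (0.30 log units; within the scatter)), so the low numbers of both go with that side chain. No measurement on hand accounts for the difference at this place.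

As far as these compounds go, whether a methoxy, a primary amine or a longer hydroxyalkyl chain at this place would match hydroxy remains open. Also open, from the compounds shown here alone, is how dimethylamino on this chain would read on the core of compound 1.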